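The source may report more compounds than this note shows. Statements on the series, on what has been measured and on what is new or still open speak of the compounds shown alone.

Of the compounds shown here, two have so far been measured in a functional assay on cells for antagonist activity at prostaglandin D2 receptor 2 (Homo sapiens), read by ELISA, chemiluminescence and cAMP accumulation, with stated times of 10 min and 60 min; a lower number here means a stronger inhibitor, a higher number a weaker inhibitor. Compound 1 `O=C(O)COC(=O)N(C1CC1)[C@H]1c2ccccc2N(C(=O)c2ccc(OC(F)(F)F)cc2)[C@H]2CC[C@H]21` gives 0.9 nM, while compound 2 `O=C(O)CCC(=O)N(C1CC1)[C@H]1c2ccccc2N(C(=O)c2ccc(F)cc2)[C@H]2CC[C@H]21` gives 20 nM, the higher of the two numbers, with a gap to compound 1 that lies beyond the scatter. Compound 3 `O=C(O)COC(=O)N(C1CC1)[C@H]1c2ccccc2N(C(=O)c2ccc(F)cc2)[C@H]2CC[C@H]21` differs from compound 2 in a single place: carboxymethoxy in place of 2-carboxyethyl on a carbonyl carbon. For the measured compounds named here, this is one of the two places in which compound 2 also differs from compound 1, so no measured pair isolates it. Since compound 1 gives 0.9 nM, compound 3 is expected to move toward it, with an estimated step of a 5.0-fold lower number from compound 2 to compound 3 (0.70 log units; beyond the scatter). The estimate for compound 3 is 4 nM, within 1.5 nM to 12 nM.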

Compound 3, half-maximal inhibitory concentration: 2 nM
Estimate against measurement, compound 3: 2.0-fold (0.30 log units) above, within the range that was stated.
By their numbers in this assay, from the lowest: compound 1; then compound 3; then compound 2.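

In this assay, for the compounds shown here, carboxymethoxy in place of 2-carboxyethyl on a carbonyl carbon, with all else unchanged, gives a 10-fold lower number from compound 2 to compound 3 (1.00 log units; beyond the scatter), the first clean reading of this change. Compound 3 also isolates the aromatic substituent: fluoro in place of trifluoromethoxy gives a 2.2-fold higher number from compound 1 to compound 3 (0.35 log units; beyond the scatter). Nothing measured here explains either step. From the compounds shown here alone, it remains open whether a carboxymethylamino group or a longer chain on that carbonyl carbon would match carboxymethoxy. Going by these compounds, it is also open whether the first step would be the same size with trifluoromethoxy on the aromatic carbon.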